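Three Aryl Variants and a Trifluoromethyl Newcomer

The source may hold more compounds than are shown below. What is called first, only, known or untested is meant among the compounds shown, and "the series" means these compounds.

Three compounds sharing one core differ only in the aryl group that ends the unsaturated chain. In an ADME assay on L6 cells (Rattus norvegicus) for cytotoxicity, read by resazurin assay, with a stated time of 70 h (a lower number here means a stronger inhibitor, a higher number a weaker inhibitor), compound 1 `COc1ccc(/C=C/C(=O)NNC(=O)NCCCC(C)Nc2cc(OC)cc3cccnc23)cc1` gives 3600 nM. Compound 2 `COc1cc(NC(C)CCCNC(=O)NNC(=O)/C=C/c2ccc(Cl)cc2)c2ncccc2c1` gives 7300 nM in this assay, and compound 3 `COc1cc(NC(C)CCCNC(=O)NNC(=O)/C=C/c2ccccc2F)c2ncccc2c1` gives 25100 nM. Compound 3 therefore stands with the highest number of the three, so the weakest inhibitor here; the step of a 2.0-fold higher number from compound 1 to compound 2 (0.31 log units; beyond the scatter) is the smaller one, while a 7.0-fold higher number from compound 1 to compound 3 (0.84 log units; beyond the scatter) and a 3.4-fold higher number from compound 2 to compound 3 (0.54 log units; beyond the scatter) both run in the same direction toward compound 3.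

Compound 4 `COc1cc(NC(C)CCCNC(=O)NNC(=O)/C=C/c2cccc(C(F)(F)F)c2)c2ncccc2c1` continues this series of aryl changes: 3-(trifluoromethyl)phenyl in place of 2-fluorophenyl on a double-bonded chain carbon bound to a double-bonded chain carbon. For the measured compounds named here, no measured step shows this exact exchange, but the three measured steps all concern the same aryl position and together span a modest range, with the exchange from compound 2 to compound 3 being the nearest analogue of an aryl swap that leaves the rest untouched. Nothing among these compounds tells whether a trifluoromethyl substituent should move the number in either direction.

On that basis the step of a 2.5-fold lower number from compound 3 to compound 4 (0.40 log units; beyond the scatter) is expected, placing compound 4 back inside the range covered by the measured compounds. For compound 4 an estimate in this assay of 10000 nM is made, with a range from 3000 nM to 40000 nM.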

Compound 4, half-maximal inhibitory concentration: 10600 nM
Estimate against measurement, compound 4: 1.1-fold (0.03 log units) below; the measured number falls inside the stated range.
By their numbers in this assay, from the lowest: compound 1; then compounds 2 and 4 (each within the scatter of the next); then compound 3.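

In this assay, the 3-(trifluoromethyl)phenyl group brings the number back down from the value seen with 2-fluorophenyl, a 2.4-fold lower number from compound 3 to compound 4 (0.37 log units; beyond the scatter), which leaves compound 3 as the weakest inhibitor of the four, with its steps to all the others beyond the scatter. Set against the 4-chlorophenyl group, the same exchange gives a 1.5-fold higher number from compound 2 to compound 4 (0.16 log units; within the scatter), so these two aryl groups cannot be told apart here despite their different substituents, while against the 4-methoxyphenyl group it gives a 2.9-fold higher number from compound 1 to compound 4 (0.47 log units; beyond the scatter), which keeps compound 1 as the strongest inhibitor of the four. No measured evidence is available to account for these differences at the aryl position.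

Each of the four aryl groups carries a different substituent in a different named place, so the kind of substituent and its place on the ring cannot be separated with these compounds. As far as these compounds go, how an unsubstituted phenyl, or an aryl group bearing an amine or a carboxylic acid, would stand in this assay also remains open.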